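Solubility from compound 1 to compound 4

The source may hold more compounds than are shown below. What is called first, only, known or untested is meant among the compounds shown, and "the series" means these compounds.

Measured so far in a physicochemical assay for solubility, read by HPLC, using the shake flask method, in phosphate buffer, with a stated time of 20 h, at pH 6.5 (a higher number here means a more soluble compound, a lower number a less soluble compound), for three compounds:
compound 1 `O=C1CN(c2nccc3[nH]c(-c4ccc(F)c(F)c4)nc23)CCN1` reads < 5000 nM (a limit)
compound 2 `C[C@@H]1CN(c2nccc3[nH]c(-c4ccc(F)c(F)c4)nc23)C[C@H](C)N1C` reads 50000 nM
compound 3 `Fc1ccc(-c2nc3c(N4CCCN(CC5CC5)CC4)nccc3[nH]2)cc1F` reads 200000 nM

Compound 1 reads < 5000 nM in this assay and that is a limit, not a number. Its standing is the limit of < 5000 nM in this assay, at which 1 of the 3 values shown sits, and nothing closer is known. The step to compound 4 `NC1CCN(c2nccc3[nH]c(-c4ccc(F)c(F)c4)nc23)CC1` puts 4-aminopiperidin-1-yl in place of 3-oxopiperazin-1-yl on an aromatic carbon, next to the ring nitrogen: 4-aminopiperidin-1-yl in place of 3-oxopiperazin-1-yl on an aromatic carbon is the full count of that change. Going by the values given here, no measured step covers this change. The expectation rests on compound 2 at 50000 nM and compound 3 at 200000 nM which both give numbers and lack the 3-oxopiperazin-1-yl group. In this assay a rise beyond the scatter is expected, estimated as an at least 20-fold higher number from compound 1 to compound 4 (1.30 log units; beyond the scatter) for this change. Compound 4 is expected to read 100000 nM with an estimated range of 30000 nM to 300000 nM in this measurement.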

Compound 4, solubility: 200000 nM
Beside the measured number, compound 4's estimate is 2.0-fold (0.30 log units) below it; low and high end bracket the measured number.
By their numbers in this assay, from the lowest: compound 2; then compounds 3 and 4 (each within the scatter of the next). At a limit, below all of these: compound 1.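

Compound 1 reads < 5000 nM in this assay, and that is a limit, not a number. Going by these compounds alone, on an aromatic carbon next to the ring nitrogen, 4-aminopiperidin-1-yl in place of 3-oxopiperazin-1-yl gives the first step here with the rest of the molecule unchanged: an at least 40-fold higher number from compound 1 to compound 4 (1.60 log units; beyond the scatter). The size of that step rests on a limit: the limit of < 5000 nM in this assay, at which 1 of the 4 values shown sits.

The compounds shown do not separate the loss of the carbonyl from the entry of the amine. As far as these compounds go, whether a plain piperazin-1-yl or a morpholine at this place would read like compound 4 stays open.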